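The source may report more compounds than this note shows. Statements on the series, on what has been measured and on what is new or still open speak of the compounds shown alone.

Measured so far:
compound 1 `Cc1cc(NS(=O)(=O)c2ccc(N/C(S)=N\c3ccnc4cc(C(F)(F)F)ccc34)cc2)on1` with 60200 nM in a functional assay on HeLa cells (Homo sapiens) for antiproliferative activity, read by sulforhodamine B assay, with a stated time of 48 h; a higher number here means a weaker inhibitor, a lower number a stronger inhibitor;
compound 2 `O=S(=O)(Nc1ccccn1)c1ccc(N/C(S)=N\c2ccnc3cc(C(F)(F)F)ccc23)cc1` with 68800 nM in this assay.

Compound 2 stands with compound 1 at the weak end of the measured range, the two numbers within the usual scatter of each other; the step of a 1.1-fold higher number from compound 1 to compound 2 (0.06 log units; within the scatter) shows that exchanging one heteroaryl on the sulfonamide nitrogen for another left the number where it was.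

Compound 3 `COc1cc(NS(=O)(=O)c2ccc(N/C(S)=N\c3ccnc4cc(C(F)(F)F)ccc34)cc2)nc(OC)n1` carries the change (2,6-dimethoxypyrimidin-4-yl in place of pyridin-2-yl on a sulfonamide nitrogen). Among the compounds with values here, only one measured step bears on this: the exchange of heteroaryl at the same place from compound 1 to compound 2, which did not move the number beyond the scatter. Within the data shown here, no other pair speaks to a 2,6-dimethoxypyrimidin-4-yl group. On that basis compound 3 is expected to stay close to compound 2, with an expected step of a 1.1-fold lower number from compound 2 to compound 3 (0.02 log units; within the scatter) in this assay. The estimate for compound 3 in this assay is 65000 nM, with a range from 25000 nM to 170000 nM.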

Compound 3, half-maximal inhibitory concentration: 53800 nM
The estimate for compound 3 lay 1.2-fold (0.08 log units) above the measured number; measured number inside the range.
By their numbers in this assay, from the lowest: compounds 3, 1 and 2 (each within the scatter of the next).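

In this assay, 2,6-dimethoxypyrimidin-4-yl on the sulfonamide nitrogen gives a 1.3-fold lower number from compound 2 to compound 3 (0.11 log units; within the scatter) and a 1.1-fold lower number from compound 1 to compound 3 (0.05 log units; within the scatter), both inside the scatter. This holds even though the entering group has more heavy atoms and more hydrogen-bond acceptors than pyridin-2-yl, so compound 1, compound 2 and compound 3 form a single band with no order among them. No measurement on hand accounts for this lack of separation.

From the compounds shown here alone, whether any substituent on this nitrogen can separate from that band remains open, for instance a saturated amine such as piperidine, a carboxylic acid or a longer alkyl chain in place of the heteroaryl ring. Going by these compounds, it is equally open whether exchanging the trifluoromethyl group on the shared core for a nitrile or a methoxy group would move the number.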